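Propyl to ethyl carbamate on the selenocyanate core

The source may hold more compounds than are shown below. What is called first, only, known or untested is meant among the compounds shown, and "the series" means these compounds.

Compound 1 `CCCOC(=O)Nc1ccc([Se]C#N)cc1` in a functional assay on HT-29 cells (Homo sapiens) for cytotoxicity, read by MTT assay, with a stated time of 72 h (a lower number here means that less compound is tolerated, a higher number that more compound is tolerated), gives 75400 nM. Compound 2 `CCOC(=O)Nc1ccc([Se][Se]c2ccc(NC(=O)OCC)cc2)cc1`, carrying the ethyl carbamate on a diselenide-bridged pair of the aryl groups, in this assay gives 76100 nM; the two numbers sit within the scatter of each other, so neither compound can be set apart from the other on this assay. Compound 3 `CCOC(=O)Nc1ccc([Se]C#N)cc1` is not yet measured. It differs from compound 1 by hydrogen in place of methyl on a saturated chain carbon, two bonds along the chain from an oxygen next to a carbonyl group, that is, propoxy becomes ethoxy on the carbamate. Within the data shown here, no measured pair shows this change alone, and compound 2 shares the ethyl carbamate but also a different selenium group, so it gives no clean guide. The step is expected to be small, with no direction beyond the scatter, estimated as a 1.0-fold lower number from compound 1 to compound 3 (0.00 log units; within the scatter). Compound 3 in this assay is therefore expected near 75000 nM, within a range of 30000 nM to 190000 nM.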

Compound 3, concentration lethal to 50% of the cells: 66600 nM
The estimate for compound 3 lay 1.1-fold (0.05 log units) above the measured number; the measured number falls inside the stated range.
By their numbers in this assay, from the lowest: compounds 3, 1 and 2 (each within the scatter of the next).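

Hydrogen in place of methyl on this saturated chain carbon, seen here alone for the first time, gives a 1.1-fold lower number from compound 1 to compound 3 (0.05 log units; within the scatter) in this assay. Propyl and ethyl at this end of the carbamate therefore cannot be told apart on this read-out, something compound 2 could not show, since it carries the ethyl carbamate together with a different selenium group. Nothing at hand offers an explanation for this step.

On these data alone, this single step covers only the short end of the chain, so it remains open whether a longer chain such as butyl, or a bulkier group such as benzyl, would also stay within the scatter. As far as these compounds go, it is equally open whether a carboxylic acid or an amine at the end of the chain would shift the number on the core of compound 1.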